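A Fluorine Added Where Both Neighbours Sit at the Limit

The source may report more compounds than this note shows. Statements on the series, on what has been measured and on what is new or still open speak of the compounds shown alone.

Compound 1, `COc1ccc(-n2ccc(=O)c(C(=O)Nc3ccc(Oc4ccnc5c4ccn5C)c(F)c3)n2)cc1`: in a functional assay on HepG2 cells (Homo sapiens) for cytotoxicity, read by MTT assay, with a stated time of 72 h (on this read-out higher numbers stand for weaker inhibition and lower numbers for stronger inhibition), compound 1 gives > 60000 nM, a limit.
Compound 2, `Cn1ccc2c(Oc3ccc(NC(=O)c4nn(-c5ccc(Br)cc5)ccc4=O)cc3F)ccnc21`: in this assay compound 2 gives > 60000 nM, a limit.

Compound 2 therefore stands only at the limit of this assay, with no number of its own; this is the limit of > 60000 nM in this assay, at which 2 of the 2 values shown sit. Compound 3, `Cn1ccc2c(Oc3ccc(NC(=O)c4nn(-c5ccc(Br)cc5F)ccc4=O)cc3F)ccnc21`, differs from compound 2 by fluoro in place of hydrogen on an aromatic carbon. Among the measured compounds shown here, the one measured step that bears on this part of the molecule, a step that the two limits leave unreadable from compound 1 to compound 2, cannot be read, so no size or direction beyond the scatter is expected in this assay. Compound 3 is therefore estimated at 70000 nM, between 25000 nM and 200000 nM. The step this estimate means, a step that the limit leaves unreadable from compound 2 to compound 3, is expected to be none.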

Compound 3, half-maximal inhibitory concentration: 24000 nM
For compound 3 the middle estimate is 2.9-fold (0.46 log units) above the measured one; measured number outside the range, below it.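

In this assay fluoro on this carbon of the 4-bromophenyl group, ortho to a large group, gives an at least 2.5-fold lower number from compound 2 to compound 3 (0.39 log units; beyond the scatter) and so shows a change that can be read beyond the scatter. Setting 4-bromo-2-fluorophenyl in place of 4-methoxyphenyl gives an at least 2.5-fold lower number from compound 1 to compound 3 (0.39 log units; beyond the scatter) as well, while the step between compound 1 and compound 2 cannot be read. Compound 3 alone has a number of its own, so both steps give only a smallest size: the limit of > 60000 nM in this assay, at which 2 of the 3 values shown sit.

On these data alone, whether chloro, a methyl group or an amine on the same carbon would give a similar step stays open. So does whether fluoro would act in the same way on the 4-methoxyphenyl group.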